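The source may report more compounds than this note shows. Statements on the series, on what has been measured and on what is new or still open speak of the compounds shown alone.

Compound 1 `O=C(O)c1ccccc1-c1ccc(CCc2ncc(CC3CCOCC3)[nH]2)cc1` is one of three analogues sharing a core and measured in an in vitro functional assay on cells for agonist activity at Bombesin receptor subtype-3 (Homo sapiens), read by luminescence and calcium flux; a lower number here means that less compound is needed, a higher number that more compound is needed for the effect. In this assay compound 1 gives 338 nM, the second highest of the three numbers. Compound 2 `O=C(O)c1ccccc1-c1ccc(CCc2ncc(-c3ccccc3)[nH]2)cc1` gives 4950 nM. In compound 2 phenyl stands where (oxan-4-yl)methyl stood, and the step is a 15-fold higher number from compound 1 to compound 2 (1.17 log units; beyond the scatter). Compound 3 `CC(C)(C)CCc1cnc(CCc2ccc(-c3ccccc3C(=O)O)cc2)[nH]1` gives 39 nM, reached by an 8.7-fold lower number from compound 1 to compound 3 (0.94 log units; beyond the scatter); the two ends of the series are joined by a 130-fold lower number from compound 2 to compound 3 (2.10 log units; beyond the scatter).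

Compound 4 `O=C(O)c1ccccc1-c1ccc(CCc2ncc(Cc3cccc(F)c3)[nH]2)cc1` differs from compound 1 by 3-fluorophenyl in place of oxan-4-yl on a saturated chain carbon bound to an aromatic carbon. The step to compound 2 bears on it, since an aromatic ring enters there too, though in compound 4 the ring stays one bond further out, as in compound 1. The step to compound 3 shows the saturated chain carbon tolerates a hydrocarbon group well. Because a 15-fold higher number from compound 1 to compound 2 (1.17 log units; beyond the scatter) was large and unfavourable, the estimate for compound 4 leans toward a higher number, but a smaller step is expected, a 2.1-fold higher number from compound 1 to compound 4 (0.32 log units; beyond the scatter). Compound 4 is therefore expected to give about 700 nM, in a range from 180 nM to 2800 nM.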

Compound 4, half-maximal effective concentration: 159 nM
For compound 4 the middle estimate is 4.4-fold (0.64 log units) above the measured one; the measured number lies below the stated range.
By their numbers in this assay, from the lowest: compound 3; then compound 4; then compound 1; then compound 2.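

With 3-fluorophenyl in place of oxan-4-yl, a 2.1-fold lower number from compound 1 to compound 4 (0.33 log units; beyond the scatter) in this assay shows that an aromatic ring on the saturated chain carbon bound to an aromatic carbon is compatible with a lower number, which compound 2 alone could not show. Against phenyl on the aromatic carbon, 3-fluorobenzyl gives a 31-fold lower number from compound 2 to compound 4 (1.49 log units; beyond the scatter) and so separates a ring carried through that saturated carbon from one attached without it. The aromatic group does not match the hydrocarbon group, however, as neopentyl gives way to 3-fluorophenyl with a 4.1-fold higher number from compound 3 to compound 4 (0.61 log units; beyond the scatter) in this series.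

Nothing available here explains these steps. The compounds shown leave open whether the fluorine contributes to the gain, as they include neither an unsubstituted benzyl nor a pyridylmethyl group for comparison.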